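Three Fluorines in Place of One on the Cinnamoyl Phenyl

This account rests on a few compounds, and the source may have more. Where it says the series, first, only, none or still open, it means among the compounds named here.

Measured in a functional assay on ME-180 cells (Homo sapiens) for cytotoxicity, read by MTT assay, with a stated time of 72 h; a lower number here means a stronger inhibitor, a higher number a weaker inhibitor:
Compound 1, `COc1ccc(/C=C/C(=O)Nc2cc(C(=O)c3cc(OC)c(OC)c(OC)c3)cc(OC)c2OC)cc1OC`, gives 6700 nM.
Compound 2, `C#CCOc1cccc(/C=C/C(=O)Nc2cc(C(=O)c3cc(OC)c(OC)c(OC)c3)cc(OC)c2OC)c1`, gives 8400 nM.
Compound 3, `COc1cc(C(=O)c2cc(OC)c(OC)c(OC)c2)cc(NC(=O)/C=C/c2ccc(F)cc2)c1OC`, gives 1000 nM.

All three share one core and differ only in the aryl group on the double-bonded chain carbon. Compound 3 has the lowest number of the three: the step of a 6.7-fold lower number from compound 1 to compound 3 (0.83 log units; beyond the scatter) and the step of an 8.4-fold lower number from compound 2 to compound 3 (0.92 log units; beyond the scatter) both lie beyond the scatter, whereas a 1.3-fold higher number from compound 1 to compound 2 (0.10 log units; within the scatter) does not. So swapping two oxygen-bearing aryl groups for a 4-fluorophenyl is the one change that has mattered so far.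

Compound 4, `COc1cc(C(=O)c2cc(OC)c(OC)c(OC)c2)cc(NC(=O)/C=C/c2cc(F)c(F)c(F)c2)c1OC`, carries the change (3,4,5-trifluorophenyl in place of 4-fluorophenyl on a double-bonded chain carbon bound to a double-bonded chain carbon). Both steps that bear on this position end at compound 3, and both were of modest size. Within the data shown here, there is no measured pair that sets one fluorine against three on this ring, so the direction of the next step is open. The expectation is a step of a 1.5-fold higher number from compound 3 to compound 4 (0.18 log units; within the scatter) of modest size at most, with a real chance it stays within the scatter. Compound 4 is therefore expected to give about 1500 nM, within 400 nM to 6000 nM.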

Compound 4, half-maximal inhibitory concentration: 7100 nM
For compound 4 the middle estimate is 4.7-fold (0.68 log units) below the measured one; measured number outside the range, above it.
By their numbers in this assay, from the lowest: compound 3; then compounds 1, 4 and 2 (each within the scatter of the next).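

Adding fluorines to this ring is not a neutral change: 3,4,5-trifluorophenyl in place of 4-fluorophenyl gives up the advantage seen so far (a 7.1-fold higher number from compound 3 to compound 4 (0.85 log units; beyond the scatter)), so the low number of compound 3 cannot be credited to fluorine on the ring as such. The trifluorinated compound instead lines up with the two compounds carrying oxygen-bearing aryl groups (a 1.2-fold lower number from compound 2 to compound 4 (0.07 log units; within the scatter); a 1.1-fold higher number from compound 1 to compound 4 (0.03 log units; within the scatter)), which means that in this assay three quite different aryl groups read alike and, among these four compounds, only the 4-fluorophenyl group stands apart. Nothing available here accounts for this difference.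

The compounds shown leave open whether the number of fluorines or their places on the ring decides the outcome, a question a difluorophenyl group could help to settle. They also leave open whether the low number of compound 3 depends on fluorine itself, or whether a 4-chlorophenyl, 4-methylphenyl or 4-cyanophenyl group on the same double-bonded chain carbon would give a similar number.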